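A few compounds are considered here, and "the series" means these few. Any claim that something is new, unique, unknown or untested is made for them only; others in the source may bear on it.

Measured compounds:
Compound 1, `CCCCCCCc1cn(C(c2ccccc2)c2cc3cc(Br)ccc3nc2OC)nn1`: 16.6%
Compound 2, `CCCCc1cn(C(c2ccccc2)c2cc3cc(Br)ccc3nc2OC)nn1`: 5.46%

Going by the values given here, compound 1 stands highest of the two numbers in an ADME assay on PANC-1 cells (Homo sapiens) for cytotoxicity, read by sulforhodamine B assay, with a stated time of 48 h, tested at 10 uM; a higher number here means more inhibition at the concentration tested (going by the name of the read-out), a lower number less inhibition; compound 2 is its only neighbour, and the step of a number 11.1 percentage points lower from compound 1 to compound 2 (beyond the scatter) lies beyond the scatter. Compound 3, `COc1nc2ccc(Br)cc2cc1C(c1ccccc1)n1cc(CCCCCO)nn1`, has not yet been measured in this assay. It differs from compound 1 in one place: hydroxy in place of ethyl on a saturated chain carbon, five bonds along the chain from an aromatic carbon. Among the compounds with values here, the only measured step that bears on this change is the shortening of the same chain in a number 11.1 percentage points lower from compound 1 to compound 2 (beyond the scatter), which took the number down by a modest amount. Within the data shown here, the change to compound 3 also shortens the chain, and in addition a hydroxy enters, on which no measured pair gives any information. A step downward of a similar modest size is therefore expected in this assay, a number 10.6 percentage points lower from compound 1 to compound 3 (beyond the scatter), with the added hydroxy leaving the size uncertain. Compound 3 is estimated at 6%, within the range -6% to 18%.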

Compound 3, a percentage reported as inhibition, at one concentration (the size of the read-out at that concentration, not a potency): 19.6%
Beside the measured number, compound 3's estimate is 13.6 percentage points below it, outside the stated range (above it).
By their numbers in this assay, from the lowest: compound 2; then compounds 1 and 3 (each within the scatter of the next).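

In this assay, hydroxy in place of ethyl on a saturated chain carbon, five bonds along the chain from an aromatic carbon, gives a number 3 percentage points higher from compound 1 to compound 3 (within the scatter), so this change leaves the two compounds indistinguishable in this read-out. Read from the other side, hydroxymethyl in place of hydrogen on a saturated chain carbon, four bonds along the chain from an aromatic carbon, gives a number 14.1 percentage points higher from compound 2 to compound 3 (beyond the scatter), which sets the earlier a number 11.1 percentage points lower from compound 1 to compound 2 (beyond the scatter) in a new light: chain length alone no longer accounts for the numbers, and compound 3 goes against any such reading. No measurement at hand gives a reason for this behaviour of the hydroxy-ended chain.

The compounds shown leave open whether the hydroxy itself matters or whether any group at the chain end would serve as well, as an amine or a carboxylic acid in the same place might show. They also leave open how a shorter chain with the same end, such as 3-hydroxypropyl, or a longer chain ending in hydroxy would read at this one concentration.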